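Trifluoromethyl for chloro across two related cores

The source may report more compounds than this note shows. Statements on the series, on what has been measured and on what is new or still open speak of the compounds shown alone.

Three compounds of this set have been run in a functional assay on MDA-MB-468 cells (Homo sapiens) for cytotoxicity, read by sulforhodamine B assay, with a stated time of 48 h; on this read-out higher numbers stand for weaker inhibition of growth and lower numbers for stronger inhibition of growth. Compound 1 `NC(=S)N/N=C1/C(=O)N(CN2CCN(c3ccnc4cc(Cl)ccc34)CC2)c2cccc(Cl)c21` gives 57600 nM in this assay. Compound 3 `NC(=S)N/N=C1/C(=O)N(CN2CCN(c3ccnc4cc(C(F)(F)F)ccc34)CC2)c2cccc(Cl)c21` differs from it by trifluoromethyl in place of chloro on an aromatic carbon and gives 23000 nM in this assay; the resulting step is a 2.5-fold lower number from compound 1 to compound 3 (0.40 log units; beyond the scatter). Compound 2 `NC(=S)N/N=C1/C(=O)N(CN2CCN(c3ccnc4cc(Cl)ccc34)CC2)c2cc(Cl)ccc21` has the same atoms as compound 1 joined differently, and the difference between the two cores is not broken down here. In this assay compound 2 gives 26500 nM; against compound 3 the two numbers lie within the usual scatter of each other, while against compound 1 the gap lies beyond it.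

Compound 4 `NC(=S)N/N=C1/C(=O)N(CN2CCN(c3ccnc4cc(C(F)(F)F)ccc34)CC2)c2cc(Cl)ccc21` has not yet been measured. It differs from compound 2 by trifluoromethyl in place of chloro on an aromatic carbon, and the place description is the same word for word as for the change from compound 1 to compound 3, so the two are the same change made on the two cores. Going by the values given here, only one measured instance of this change exists, so the expectation rests on a single step, a 2.5-fold lower number from compound 1 to compound 3 (0.40 log units; beyond the scatter), transferred to compound 2 and its value of 26500 nM. On that basis compound 4 is expected to give 11000 nM in this assay, with a range estimated from 5000 nM to 28000 nM. The step this estimate implies is a 2.4-fold lower number from compound 2 to compound 4 (0.38 log units; beyond the scatter), expected to be of the same size as the one measured between the other two compounds. Whether the second core carries the change the same way remains to be seen.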

Compound 4, concentration for 50% growth inhibition: 11000 nM
For compound 4 middle estimate and measured number coincide at the digits printed, and the stated range covers the measured number.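

In this assay, trifluoromethyl in place of chloro on an aromatic carbon gives a 2.4-fold lower number from compound 2 to compound 4 (0.38 log units; beyond the scatter) and so repeats on the second core the step seen on the first, with no difference in size that stands out from the scatter: the same change on two cores in this assay, a 2.5-fold lower number (0.40 log units; beyond the scatter) from compound 1 to compound 3 and a 2.4-fold lower number (0.38 log units; beyond the scatter) from compound 2 to compound 4, 1.0-fold (0.02 log units) apart, within the scatter of two such steps

For these two cores, then, the step measured on one core served as a fair guide to the step on the other, and treating the change as transferable between them is supported by this pair of matched steps. That support is narrow, resting on two steps, one exchange of groups, one cell line and one read-out, and it shows neither why the step has this size nor that it would hold on any further core of the series.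

The compounds shown leave open how other groups on the same aromatic carbon would behave, for instance a nitrile, a methoxy group, an amine or a carboxylic acid, and whether any of them would move the number further than trifluoromethyl does. Also open, from the compounds shown here alone, is whether the step keeps its size on a third core or in other cell lines, which would show how far the transfer seen here can be relied on.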